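Trimming the Amide Substituent of a Diaryl Urea Benzamide

The source may hold more compounds than are shown below. What is called first, only, known or untested is meant among the compounds shown, and "the series" means these compounds.

Compound 1, `CC(NC(=O)c1cccc(-c2ccc(NC(=O)Nc3ccc(Cl)c(C(F)(F)F)c3)cc2)c1)c1ccccc1`, was tested in a functional assay on HT-29 cells (Homo sapiens) for inhibition, read by MTT assay, with a stated time of 120 h (on this read-out lower numbers stand for stronger inhibition and higher numbers for weaker inhibition), and gives 6320 nM. Among the numbers shown it has the highest of the numerical readings, yet its nearest neighbour, compound 3, `CC(NC(=O)c1ccc(-c2ccc(NC(=O)Nc3ccc(Cl)c(C(F)(F)F)c3)cc2)cc1)c1ccccc1`, gives 5960 nM, and the gap between the two lies within the scatter of the assay, so no order can be drawn between them. Compound 2, `C/C(=C\C(=O)NC(C)c1ccccc1)c1ccc(NC(=O)Nc2ccc(Cl)c(C(F)(F)F)c2)cc1`, returns only a limit of the assay, > 50000 nM, and this is the case described by the limit of > 50000 nM in this assay, at which 1 of the 3 values shown sits. No pair among these measured compounds differs in a single place, so no measured step is available to guide a prediction.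

The unmeasured compound 4, `CNC(=O)c1cccc(-c2ccc(NC(=O)Nc3ccc(Cl)c(C(F)(F)F)c3)cc2)c1`, departs from compound 1 in one place: methyl in place of 1-phenylethyl on an amide-type nitrogen. The 1-phenylethyl group thus gives way to the smaller methyl while the rest of the shared core is kept. The numbers shown hold no measured step of this kind, and the expectation rests only on the group that leaves. The step of a 2.4-fold higher number from compound 1 to compound 4 (0.38 log units; beyond the scatter) is expected to run towards weaker inhibition, beyond the usual scatter but not by a large margin. Compound 4 is therefore estimated at 15000 nM, within a range from 4000 nM to 50000 nM.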

Compound 4, half-maximal inhibitory concentration: 29300 nM
Compound 4: middle estimate off by 2.0-fold (0.29 log units), on the low side; the measured number falls inside the stated range.
By their numbers in this assay, from the lowest: compounds 3 and 1 (each within the scatter of the next); then compound 4. At a limit, above all of these: compound 2.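

In this assay, within the data shown here, the change from 1-phenylethyl to methyl on the amide-type nitrogen gives the first single-place comparison, and it runs towards weaker inhibition (a 4.6-fold higher number from compound 1 to compound 4 (0.67 log units; beyond the scatter)), which shows that the reading at this position does respond to the group carried there. The step is modest, however, and compound 4 still returns a number (29300 nM) rather than a limit of the assay, so a reading survives even with the aromatic ring and the branched carbon of the 1-phenylethyl group gone. Among these compounds, the single step removes both features at once and cannot separate them, and nothing measured here accounts for the difference between the two groups.

The compounds shown leave open which part of the 1-phenylethyl group matters: benzyl would keep the ring without the branch, while isopropyl would keep the branch without the ring, and a longer chain such as n-butyl would test size alone. They also leave open whether the same exchange of 1-phenylethyl for methyl would carry the same step on compound 3, where the amide sits differently on the shared core.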